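The compounds below may be only part of what the source reports. "The series", "measured", "known", "first", "only" and "open" are said of these compounds alone.

In a functional assay on the whole organism (strain C57BL/6L) for inhibition, with Mus musculus as the target, read by paw edema, with stated times of 30 min and 76 h, at a dose of 10 mg/kg by the intraperitoneal route (a higher number here means more inhibition at the dose given (going by the name of the read-out), a lower number less inhibition), compound 1 `c1ccc(NCc2ccc(CNc3ccccn3)cc2)nc1` is recorded only as "active" (no number reported), with no figure behind it. For the measured compounds named here, compound 2 `CSc1ccnc(NCc2ccc(CNc3ncc(F)cn3)cc2)n1` in this assay gives 20%, which is the only number available, so it stands alone on the scale with nothing to rank against. Compound 3 `Fc1cnc(NCc2ccc(CNc3nccc(C(F)(F)F)n3)cc2)nc1` differs from compound 2 by trifluoromethyl in place of methylsulfanyl on an aromatic carbon. Going by the values given here, no measured pair shows this change, so its effect in this assay is unknown; the step is expected to stay within the scatter, with no clear direction. Compound 3 is expected to give about 22%, within 5% to 40%. The expected step is a number 2 percentage points higher from compound 2 to compound 3 (within the scatter).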

Compound 3, a percentage reported as inhibition, in the whole organism at one dose (the size of the read-out at that dose, not a potency): 20%
Compound 3: the middle estimate sits 2 percentage points above what was measured; low and high end bracket the measured number.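

In this assay the read-out shows no change at the digits printed from compound 2 to compound 3 (within the scatter) when trifluoromethyl, with 4 heavy atoms, takes the place of methylsulfanyl, with 2, on the aromatic carbon. For the compounds shown here, this gives the first readable step at this position, and it shows that this exchange, which also removes the hydrogen-bond acceptor counted for methylsulfanyl, leaves the inhibition at the dose given within the scatter. No measurement available here explains this outcome.

On these data alone, whether an amine, a carboxylic acid or a longer chain at this position would move the read-out remains open. A single exchange also cannot show how other groups would behave here.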